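Pyridin-3-yl for 4-nitrophenyl on the carbonyl

The compounds below may be only part of what the source reports. "The series", "measured", "known", "first", "only" and "open" are said of these compounds alone.

In a functional assay on MDA-MB-231 cells (Homo sapiens) for antiproliferative activity, with a stated time of 4 days (on this read-out lower numbers stand for stronger inhibition and higher numbers for weaker inhibition), compound 3 (`CCCCc1ccc2[nH]c(-c3ccc(OC)cc3)c(/C=N/NC(=O)c3ccc([N+](=O)[O-])cc3)c2c1`) gives 115 nM as the highest number of the set, with compound 1 (`CCCCc1ccc2[nH]c(-c3ccc(OC)cc3)c(/C=N/O)c2c1`) at 40 nM and compound 2 (`CCCCc1ccc2[nH]c(-c3ccc(OC)cc3)c(/C=N/NC(=O)c3ccc(F)cc3)c2c1`) at 19 nM on the same read-out. Compound 4 (`CCCCc1ccc2[nH]c(-c3ccc(OC)cc3)c(/C=N/NC(=O)c3cccnc3)c2c1`) differs from compound 3 by pyridin-3-yl in place of 4-nitrophenyl on a carbonyl carbon with pyridin-3-yl in place of 4-nitrophenyl on a carbonyl carbon. The closest evidence is the modest 6.1-fold higher number from compound 2 to compound 3 (0.78 log units; beyond the scatter) when nitro replaces fluoro on an aromatic carbon, while the modest 2.1-fold lower number from compound 1 to compound 2 (0.32 log units; beyond the scatter) reflects a larger exchange. Among the measured compounds shown here, no measured compound carries pyridin-3-yl, so a modest move toward a lower number is only expected. The expected change is a 2.1-fold lower number from compound 3 to compound 4 (0.32 log units; beyond the scatter) in this assay for this exchange. Compound 4 is estimated at 55 nM with a range from 18 nM to 170 nM for now.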

Compound 4, half-maximal inhibitory concentration: 35 nM
Compound 4: the middle estimate sits 1.6-fold (0.20 log units) above what was measured; low and high end bracket the measured number.
By their numbers in this assay, from the lowest: compounds 2, 4 and 1 (each within the scatter of the next, the first and the last beyond it); then compound 3.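

In this assay, the group on the carbonyl carbon again moves the read-out, with a 3.3-fold lower number from compound 3 to compound 4 (0.52 log units; beyond the scatter), and a pyridin-3-yl ring now joins the comparison. Beside the other two compounds, the differences stay within the scatter, with a 1.8-fold higher number from compound 2 to compound 4 (0.27 log units; within the scatter) and a 1.1-fold lower number from compound 1 to compound 4 (0.06 log units; within the scatter), so among these four only 4-nitrophenyl stands apart. Nothing available gives a cause for these differences.

Going by these compounds, whether pyridin-4-yl, or a phenyl carrying an amine, on the carbonyl carbon would stay with compound 4 or move toward compound 3 remains open.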